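This account rests on a few compounds, and the source may have more. Where it says the series, first, only, none or still open, it means among the compounds named here.

Compound 1 `OC(CCn1nc2c(Br)c(Br)c(Br)c(Br)c2n1)c1ccc(Br)cc1` gives 101% in a functional assay on CCRF-CEM cells (Homo sapiens) for antiproliferative activity, read by MTT assay, with a stated time of 24 h, tested at 12.5 uM; on this read-out higher numbers stand for a weaker effect at the one concentration tested and lower numbers for a stronger effect. Compound 2 `OC(CCn1nc2c(Br)c(Br)c(Br)c(Br)c2n1)c1ccccc1` gives 122%. Compound 3 `OC(CCn1nc2c(Br)c(Br)c(Br)c(Br)c2n1)c1cccc(Cl)c1` gives 110%.

On these three numbers compound 3 stands second highest: compound 1 lies nearest, with a number 9 percentage points higher from compound 1 to compound 3 (within the scatter), and compound 2 furthest, with a number 12 percentage points lower from compound 2 to compound 3 (beyond the scatter). Compound 4 `CC(O)CCn1nc2c(Br)c(Br)c(Br)c(Br)c2n1` differs from compound 3 by methyl in place of 3-chlorophenyl on a saturated chain carbon bound to an oxygen on a saturated carbon and a saturated chain carbon. Among the measured compounds shown here, no measured step removes the aromatic ring from this position; the two steps that touch it, a number 9 percentage points higher from compound 1 to compound 3 (within the scatter) and a number 12 percentage points lower from compound 2 to compound 3 (beyond the scatter), are small or within the scatter, and all three measured values sit around the level of no effect. Compound 4 is therefore expected to show a number 2 percentage points lower from compound 3 to compound 4 (within the scatter), giving an estimated 108%, within 90% to 126%.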

Compound 4, a percentage reported as activity, at one concentration (the size of the read-out at that concentration, not a potency): 106%
Compound 4: the middle estimate sits 2 percentage points above what was measured; low and high end bracket the measured number.
By their numbers in this assay, from the lowest: compounds 1, 4 and 3 (each within the scatter of the next); then compound 2.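

Putting methyl in place of the aromatic ring on this saturated chain carbon leaves the number in this assay without a clear shift, with a number 4 percentage points lower from compound 3 to compound 4 (within the scatter) and a number 5 percentage points higher from compound 1 to compound 4 (within the scatter). Among the compounds shown here, only the step from the unsubstituted phenyl goes beyond the scatter, with a number 16 percentage points lower from compound 2 to compound 4 (beyond the scatter), so an aromatic ring at this position is not required for a reading at this level. Nothing available here explains these steps. On these data alone, it remains open whether an amine, a carboxylic acid or a longer chain at this position would give a clearly stronger effect.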